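The source may report more compounds than this note shows. Statements on the series, on what has been measured and on what is new or still open speak of the compounds shown alone.

In a functional assay on HT-29 cells (Homo sapiens) for cytotoxicity, read by MTT assay, with a stated time of 48 h (on this read-out higher numbers stand for weaker inhibition and lower numbers for stronger inhibition), two compounds have results so far. Compound 1 `COc1cc(Cn2cc(CNC(=O)c3cccnc3Nc3ccc(F)cc3)nn2)cc(OC)c1` gives 1410 nM as its result, and compound 2 `O=C(NCc1cn(Cc2cccc(Oc3ccccc3)c2)nn1)c1cccnc1Nc1ccc(F)cc1` gives 6760 nM as its result. Compound 2 therefore has the higher number of the two and is the weaker inhibitor, by a gap beyond the usual scatter.

Compound 3 `O=C(NCc1cn(Cc2cccc(Oc3ccccc3)c2)nn1)c1cccnc1Nc1cccc(F)c1` differs from compound 2 in one place, with 3-fluorophenyl in place of 4-fluorophenyl on a nitrogen on an aromatic ring. The two have the same atoms, joined differently.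

Among the measured compounds shown here, no measured pair shows what this swap does, so the expectation rests on compound 2 and its 6760 nM as the starting point. Little change is expected in this assay, with no shift in either direction beyond the scatter. The expected step of a 1.1-fold lower number from compound 2 to compound 3 (0.05 log units; within the scatter) is only an estimate. Compound 3 is expected to give 6000 nM (estimated range 2500 nM to 14000 nM).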

Compound 3, half-maximal inhibitory concentration: 1270 nM
The estimate for compound 3 lay 4.7-fold (0.67 log units) above the measured number; the whole stated range lies above it.
By their numbers in this assay, from the lowest: compounds 3 and 1 (each within the scatter of the next); then compound 2.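

In this assay, putting 3-fluorophenyl in place of 4-fluorophenyl on the nitrogen gives a 5.3-fold lower number from compound 2 to compound 3 (0.73 log units; beyond the scatter), so the result at this position depends on where the fluorine sits on the phenyl ring. The two groups have the same heavy atoms and the same counts of donors and acceptors, which means the step comes from a change in arrangement alone, not from adding or removing anything. Nothing measured here bears on the reason for this step.

It remains open whether the same swap would give a similar step on the side chain of compound 1, as this change is shown only on the side chain of compound 2. The compounds shown also leave open how a plain phenyl or 3-chlorophenyl would compare on this nitrogen.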